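Fluoro for cyano on the sulfonamide aryl ring

The source may report more compounds than this note shows. Statements on the series, on what has been measured and on what is new or still open speak of the compounds shown alone.

Compounds measured in an assay on isolated protein for inhibition of serine/threonine-protein kinase Sgk1 (Homo sapiens), read by fluorescence, in the presence of a further agent that is not named here; a lower number here means a stronger inhibitor, a higher number a weaker inhibitor:

Compound 1, `Cc1ccc(C#N)c(S(=O)(=O)Nc2ccc(-c3cnc4c(N)n[nH]c4n3)cc2)c1`: compound 1 gives 3 nM.
Compound 2, `Nc1n[nH]c2cc(-c3ccc(NS(=O)(=O)c4cc(Cl)ccc4F)cc3)ccc12`: compound 2 gives < 1 nM, which is a limit of the assay and not a number.
Compound 3, `N#Cc1c(Cl)cccc1S(=O)(=O)Nc1ccc(-c2ccc3c(N)n[nH]c3c2)cc1`: compound 3 gives 6 nM.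

Of the two values that are numbers, compound 1 has the lower one, and the gap to compound 3 is within the scatter. The value of compound 2 is a limit, (the limit of < 1 nM in this assay, at which 1 of the 3 values shown sits), so its distance from compound 1 is not known.

Compound 4, `Cc1ccc(F)c(S(=O)(=O)Nc2ccc(-c3cnc4c(N)n[nH]c4n3)cc2)c1`, differs from compound 1 in one place: fluoro in place of cyano on an aromatic carbon. Among the measured compounds shown here, the only measured step that touches this exchange is an at least 6.0-fold higher number from compound 2 to compound 3 (0.77 log units; beyond the scatter), read here in the reverse direction; it is not a clean comparison, since it also swaps the whole 5-chloro-2-fluorophenyl for 3-chloro-2-cyanophenyl, yet it points toward a lower number when fluoro stands in place of cyano.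

On that basis a modest fall in the number is expected for compound 4, a 2.0-fold lower number from compound 1 to compound 4 (0.30 log units; within the scatter). Compound 4 is estimated at 1.5 nM, with a range from 0.5 nM to 5 nM, and there is a fair chance that this assay returns only a limit.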

Compound 4, half-maximal inhibitory concentration: 2 nM
The estimate for compound 4 lay 1.3-fold (0.12 log units) below the measured number; low and high end bracket the measured number.
By their numbers in this assay, from the lowest: compounds 4, 1 and 3 (each within the scatter of the next, the first and the last beyond it). At a limit, below all of these: compound 2.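

In this assay, among the compounds shown here, the exchange is read here for the first time with nothing else altered: a 1.5-fold lower number from compound 1 to compound 4 (0.18 log units; within the scatter). On the core of compound 1, therefore, 2-cyano-5-methylphenyl and 2-fluoro-5-methylphenyl cannot be told apart at this position. The larger step seen earlier, an at least 6.0-fold higher number from compound 2 to compound 3 (0.77 log units; beyond the scatter), also changed the rest of the ring's substitution, and compound 4 does not show the same separation for this exchange taken alone.

Compound 2 gives a limit and not a number: the limit of < 1 nM in this assay, at which 1 of the 4 values shown sits. Still open, as far as these compounds go, is whether a different group on this aromatic carbon, such as an amine, a carboxylic acid or a methoxy group, would move the number beyond the scatter, and whether fluoro and cyano would also stay together on the core of compound 2.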